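Amide variation on a chlorobenzoxazole thioether series

The source may hold more compounds than are shown below. What is called first, only, known or untested is meant among the compounds shown, and "the series" means these compounds.

Measured:
compound 1 `CC1CCCN1C(=O)CCSc1nc2cc(Cl)ccc2o1`: 98 mL/min/g
compound 2 `CN(CCC(=O)N1CCCC1)c1nc2cc(Cl)ccc2o1`: "not determined" (no result reported)

Within the data shown here, in an ADME assay on microsomes from liver (Mus musculus) for metabolic stability, read by LC-MS, using NADPH, with a stated time of 45 min, tested at 0.5 uM (on this read-out higher numbers stand for fast clearance and lower numbers for slow clearance), compound 1 gives 98 mL/min/g, the only number in hand, so there is no comparator among the measured compounds; for compound 2 the entry reads "not determined" (no result reported). Compound 3 `CN(C)C(=O)CCSc1nc2cc(Cl)ccc2o1` is the next entry, carrying (dimethylamino in place of 2-methylpyrrolidin-1-yl on a carbonyl carbon). Among the measured compounds shown here, no measured step covers such a change, so no size can be read off. A step from compound 1 to compound 3 of a 1.3-fold lower number from compound 1 to compound 3 (0.12 log units; within the scatter) is expected, which stays within the usual scatter, with no clear direction. For compound 3 the estimated value in this assay is 75 mL/min/g, expected between 35 mL/min/g and 150 mL/min/g.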

Compound 3, intrinsic clearance in a liver preparation (reported as CLH), per the amount of preparation that the assay uses: 41.8 mL/min/g
For compound 3 the middle estimate is 1.8-fold (0.25 log units) above the measured one; the range from low to high includes it.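

Dimethylamino in place of 2-methylpyrrolidin-1-yl on a carbonyl carbon gives a 2.3-fold lower number from compound 1 to compound 3 (0.37 log units; beyond the scatter) in this assay, the first sign that the clearance read-out responds to a change at this position. The ring of compound 1 is therefore not needed to keep a measurable clearance, and the open-chain amide of compound 3 sits lower. Nothing in hand explains the step.

This single step cannot separate loss of the ring from loss of size. As far as these compounds go, how a morpholin-4-yl or a methylamino group on the same carbonyl carbon would read remains open.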